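The compounds below may be only part of what the source reports. "The series", "measured", "known", "first", "only" and "open" are said of these compounds alone.

Compound 1 `CCOc1ccc(-c2ccc(NCc3ccccc3O)cc2)cc1` and compound 2 `CC(C)Oc1ccc(-c2ccc(NCc3ccccc3O)cc2)cc1` share one core; compound 3 `COc1ccc(-c2ccc(NCc3ccccc3O)cn2)cc1` and compound 4 `CCOc1ccc(-c2ccc(NCc3ccccc3O)cn2)cc1` share another, and the difference between the two cores is not broken down here. In a functional assay on Jurkat cells (Homo sapiens) for activation, with a stated time of 24 h (on this read-out higher numbers stand for an effect only at larger amounts of compound and lower numbers for an effect already at smaller amounts), compound 1 gives 520 nM, compound 2 gives 5940 nM and compound 3 gives 4760 nM. The change methyl in place of hydrogen on a saturated chain carbon bound to an oxygen on an aromatic ring and a saturated chain carbon produced an 11-fold higher number from compound 1 to compound 2 (1.06 log units; beyond the scatter). The change methyl in place of hydrogen on a saturated chain carbon bound to an oxygen on an aromatic ring is the same kind of change, but its place is not bound to a further saturated chain carbon, so the earlier step is only a loose guide. Because compound 1 with its ethoxy gives 520 nM, a result not far from compound 3 is expected for compound 4, and the step of a 2.4-fold lower number from compound 3 to compound 4 (0.38 log units; beyond the scatter) is the estimate. Compound 4 is expected to give about 2000 nM in this assay, within 400 nM to 10000 nM.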

Compound 4, half-maximal effective concentration: "not active" (no number reported)
Compound 4 has no reported number here; the estimate stays without a comparison.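

Among the compounds shown here, compound 4 is reported as not active, without a number, so no step from compound 3 to compound 4 can be read. The compounds shown leave open how far methoxy to ethoxy shifts this assay on this core, and no data here explain the result.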